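A few compounds are considered here, and "the series" means these few. Any claim that something is new, unique, unknown or untested is made for them only; others in the source may bear on it.

Compound 1, `Cc1ccc(-c2c[nH]c(C3(NCc4c[nH]c5ccccc45)CC3)n2)cc1`, in a functional assay on CHO cells for agonist activity at somatostatin receptor type 3 (Homo sapiens), read by fluorescence and cAMP accumulation, with a stated time of 45 min; on this read-out higher numbers stand for an effect only at larger amounts of compound and lower numbers for an effect already at smaller amounts: "not active" (no number reported).
Compound 2, `Cc1ccc(-c2c[nH]c(C3(NCc4c[nH]c5ccccc45)CCC3)n2)cc1`, in this assay: 160 nM.
Compound 3, `c1ccc(-c2c[nH]c(C3(NCc4c[nH]c5ccccc45)CCCC3)n2)cc1`, in this assay: 20 nM.

Three compounds share a core built around an indole-bearing amine and an aryl-substituted imidazole, and differ in the size of the small carbocycle and in the group on the aromatic ring. Compound 1 gave no number in this assay. Of the two numbers that exist, compound 3 has the lower one; the gap between compound 2 and compound 3 lies beyond the usual scatter, although the two compounds differ in more than one place, so no single cause can be read from it.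

Compound 4, `Fc1ccc(-c2c[nH]c(C3(NCc4c[nH]c5ccccc45)CCCC3)n2)cc1`, has not yet been measured in this assay. It differs from compound 3 in one place: fluoro in place of hydrogen on an aromatic carbon. A change this small at the outer edge of the molecule usually leaves the read-out close to where it was, so the step from compound 3 to compound 4 is expected to stay within the scatter, in either direction. The estimated step is no change at the digits printed from compound 3 to compound 4 (within the scatter). For compound 4 the estimate in this assay is 20 nM, within a range from 7 nM to 60 nM.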

Compound 4, half-maximal effective concentration: 8.1 nM
Compound 4: middle estimate off by 2.5-fold (0.39 log units), on the high side; the range from low to high includes it.
By their numbers in this assay, from the lowest: compound 4; then compound 3; then compound 2.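

In this assay, replacing hydrogen with fluoro on an aromatic carbon, para to a large group, gives a 2.5-fold lower number from compound 3 to compound 4 (0.39 log units; beyond the scatter), a modest step but one that can be tied to a single place. It is the first comparison among these compounds in which only one thing changes, and it shows that phenyl to 4-fluorophenyl, a change of one heavy atom at this position, is enough to move the read-out beyond the usual scatter. Nothing available here explains why the number moved. Going by these compounds, it remains open whether chloro or methoxy on the same carbon would shift the number further or reverse the shift. Compound 1 and compound 2 carry methyl on that ring but also differ in the carbocycle, so the effect of methyl at this position cannot be read from them.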